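Three ring-fused sulfonamides and a dichlorobenzyl analogue

This account rests on a few compounds, and the source may have more. Where it says the series, first, only, none or still open, it means among the compounds named here.

Three compounds share one core and have been run in a functional assay on MRC5 cells (Homo sapiens); a lower number here means that less compound is tolerated, a higher number that more compound is tolerated. Compound 1 `O=S1(=O)N=C(OCc2ccc(C(F)(F)F)cc2)c2ccccc2N1Cc1ccc(C(F)(F)F)cc1` gives 48000 nM in this assay. Compound 2 `Cc1ccc(CN2c3ccccc3C(=O)N(Cc3ccccc3)S2(=O)=O)cc1` gives 63000 nM in this assay. Compound 3 `COc1ccc(CN2c3ccccc3C(OCc3ccccc3)=NS2(=O)=O)cc1` gives 61000 nM in this assay. Compound 2 holds the highest of the three numbers, yet its gaps to compound 3 and to compound 1 both fall within the usual scatter, so the three values are best read as one level.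

Compound 4 `O=C1c2ccccc2N(Cc2ccc(Cl)c(Cl)c2)S(=O)(=O)N1Cc1ccccc1` has not yet been measured. It differs from compound 2 by 3,4-dichlorophenyl in place of 4-methylphenyl on a saturated chain carbon bound to a sulfonamide nitrogen in a ring. Within the data shown here, nothing among the measured compounds offers a step of this kind, and the values of compound 1, compound 2 and compound 3 sit together despite different substituents on the benzylic groups. Compound 4 is therefore expected to stay close to compound 2 in this assay, with an estimated step of a 1.4-fold lower number from compound 2 to compound 4 (0.15 log units; within the scatter) that remains within the scatter. The value for compound 4 is estimated at 45000 nM, expected between 20000 nM and 90000 nM.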

Compound 4, half-maximal cytotoxic concentration: 56000 nM
For compound 4 the middle estimate is 1.2-fold (0.09 log units) below the measured one; low and high end bracket the measured number.
By their numbers in this assay, from the lowest: compounds 1, 4, 3 and 2 (each within the scatter of the next).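

Exchanging 4-methylphenyl for 3,4-dichlorophenyl on a saturated chain carbon bound to a sulfonamide nitrogen in a ring gives a 1.1-fold lower number from compound 2 to compound 4 (0.05 log units; within the scatter) in this assay. Among these compounds, this is the first change in one place that can be read, and it shows that this position accepts the two chlorine atoms in place of the methyl group with no change beyond the scatter. No measurement shown here offers an explanation for this result.

The compounds shown leave open whether an amine or a carboxylic acid on this phenyl ring, or a longer chain in place of the benzylic carbon, would shift the number in this assay. They also leave open whether the same exchange would behave alike on the other cores in the set.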